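Imidazopyrazine series: aryl swap at the pyrazine carbon

This account rests on a few compounds, and the source may have more. Where it says the series, first, only, none or still open, it means among the compounds named here.

Measured in a functional assay on A549 cells (Homo sapiens) for inhibition, read by sulforhodamine B assay, with a stated time of 48 h, tested at 10 uM; on this read-out lower numbers stand for less inhibition and higher numbers for more inhibition at the one concentration tested (going by the name of the read-out):
Compound 1 `COc1ccc(-c2cn3ccnc3c(-c3ccc4ncn(C5CCCCC5)c4c3)n2)cc1` gives 68.6%
Compound 2 `c1cn2cc(-c3ccsc3)nc(-c3ccc4ncn(C5CCCCC5)c4c3)c2n1` gives 3.97%

Among the measured compounds shown here, the single measured step is a number 64.6 percentage points lower from compound 1 to compound 2 (beyond the scatter), which places compound 2 at the lower of the two numbers. Compound 3 `FC(F)(F)c1cccc(-c2cn3ccnc3c(-c3ccc4ncn(C5CCCCC5)c4c3)n2)c1` differs from compound 2 by 3-(trifluoromethyl)phenyl in place of thiophen-3-yl on an aromatic carbon. The measured step bears on this only partly: it contrasts a six-membered carbon ring with a five-membered ring, yet the ring entering here carries trifluoromethyl rather than methoxy, so it gives only a partial guide. In this assay an upward step is nonetheless expected, estimated as a number 31 percentage points higher from compound 2 to compound 3 (beyond the scatter), with wide uncertainty. Compound 3 is expected to give 35%, in the range 5% to 70%.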

Compound 3, a percentage reported as inhibition, at one concentration (the size of the read-out at that concentration, not a potency): 5.15%
The estimate for compound 3 lay 29.9 percentage points above the measured number; measured number inside the range.
By their numbers in this assay, from the lowest: compounds 2 and 3 (each within the scatter of the next); then compound 1.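

In this assay, replacing thiophen-3-yl with 3-(trifluoromethyl)phenyl gives a number 1.2 percentage points higher from compound 2 to compound 3 (within the scatter), so a six-membered carbon ring alone does not restore the number seen with 4-methoxyphenyl. Among the compounds shown here, replacing 4-methoxyphenyl with 3-(trifluoromethyl)phenyl gives a number 63.5 percentage points lower from compound 1 to compound 3 (beyond the scatter), leaving 4-methoxyphenyl as the only one of the three groups with a high number at this position. No evidence on the cause is at hand.

From the compounds shown here alone, it remains open whether that number depends on the methoxy group itself or on where it sits on the phenyl ring. Going by these compounds, the effect of an amine or a carboxylic acid on that ring also remains open.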